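A few compounds are considered here, and "the series" means these few. Any claim that something is new, unique, unknown or untested is made for them only; others in the source may bear on it.

For the measured compounds named here, in a functional assay on MCF7 cells (Homo sapiens) for antiproliferative activity, read by sulforhodamine B assay, with a stated time of 48 h (on this read-out lower numbers stand for stronger inhibition and higher numbers for weaker inhibition), three compounds built on a shared core have numbers so far. Compound 1 (`O=C1NCCN1c1ccc(S(=O)(=O)Nc2ccc(F)c(F)c2)cc1`) gives 620 nM, compound 2 (`O=C1NCCN1c1ccc(S(=O)(=O)Nc2ccc(OC(F)F)cc2)cc1`) gives 760 nM, and compound 3 (`COc1ccc(NS(=O)(=O)c2ccc(N3CCNC3=O)cc2)cc1OC`) gives 610 nM. Compound 3 thus stands within the scatter of both others, and these values set no order among the three.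

Compound 4 (`COc1ccc(NS(=O)(=O)c2ccc(N3CCNC3=O)cc2)cc1`) has yet to be measured in this assay. It differs from compound 3 in one place, with hydrogen in place of methoxy on an aromatic carbon, ortho to a methoxy group and meta to a large group: hydrogen in place of methoxy on an aromatic carbon. Going by the values given here, no measured pair shows this change directly. Among the compounds with values here, the only guide is the closeness of the values: compound 1 at 620 nM and compound 2 at 760 nM carry different groups from compound 3 at 610 nM, yet all three lie within the scatter. No step beyond the scatter is therefore expected, in either direction. The expected step is a 1.1-fold higher number from compound 3 to compound 4 (0.03 log units; within the scatter). Compound 4 is estimated at 650 nM, within a range of 300 nM to 1400 nM.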

Compound 4, half-maximal inhibitory concentration: > 1000 nM
Compound 4: no number, only a limit (the forecaster's own chance of this, stated with the estimate: 2%); middle value at least 1.5-fold (0.18 log units) away from the limit.
By their numbers in this assay, from the lowest: compounds 3, 1 and 2 (each within the scatter of the next). At a limit, above all of these: compound 4.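

In this assay compound 4 gives > 1000 nM, a limit of the assay and not a number. Hydrogen in place of methoxy on this aromatic carbon, ortho to a methoxy group and meta to a large group, is thus the one change here that leaves no number at all, and it gives an at least 1.6-fold higher number from compound 3 to compound 4 (0.21 log units; that floor lies within the scatter), a floor that lies within the scatter. The steps of an at least 1.3-fold higher number from compound 2 to compound 4 (0.11 log units; that floor lies within the scatter) and an at least 1.6-fold higher number from compound 1 to compound 4 (0.20 log units; that floor lies within the scatter) have floors within the scatter too, so the limit points only upward and does not establish a step beyond the scatter.

From the compounds shown here alone, how far the true step reaches stays open. So does whether an ethoxy, a hydroxyl or an amine on this carbon would give a number close to that of compound 3.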